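The source may hold more compounds than are shown below. What is called first, only, known or untested is meant among the compounds shown, and "the series" means these compounds.

Of the compounds shown here, two of one family have been tested in a functional assay on the whole organism (strain albino) with Rattus norvegicus as the target, in the maximal electroshock model, with a stated time of 1 h, at a dose of 30 mg/kg by the intraperitoneal route; on this read-out higher numbers stand for more inhibition at the one dose given (going by the name of the read-out) and lower numbers for less inhibition. Compound 1 `Cc1nc2ccc(Br)cc2c(=O)n1NCc1nnc(N2C(=O)CSC2c2ccc(O)cc2)s1` gives 60%, and compound 2 `COc1cccc(C2SCC(=O)N2c2nnc(CNn3c(C)nc4ccc(Br)cc4c3=O)s2)c1` gives 60%. Among the measured compounds shown here, the only measured step, no change at the digits printed from compound 1 to compound 2 (within the scatter), swaps one aryl group for another on a saturated ring carbon, so compound 2 stands level with compound 1 at the digits printed, within the scatter.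

Compound 3 `COc1cccc(C2SCC(=O)N2c2nnc(CNn3c(C)nc4ccccc4c3=O)s2)c1` has not been measured. It differs from compound 2 by hydrogen in place of bromo on an aromatic carbon. For the measured compounds named here, no measured step touches this part of the shared core: the one known step alters the aryl group on the saturated ring and leaves the bromo in place, so it gives no guide to the size or direction of this change. Going by the values given here, the only foothold is that compound 2 gives 60% in this assay and that the single known step shows no change beyond the scatter.

Compound 3 is therefore expected to give about 50% in this assay, with a range from 20% to 80%. The estimated step of a number 10 percentage points lower from compound 2 to compound 3 (within the scatter) is small, but the range is wide.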

Compound 3, a percentage reported as inhibition, in the whole organism at one dose (the size of the read-out at that dose, not a potency): 60%
Compound 3: the middle estimate sits 10 percentage points below what was measured; the measured number falls inside the stated range.
By their numbers in this assay, from the lowest: compounds 1, 2 and 3 (each within the scatter of the next).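

In this assay, among the compounds shown here, putting hydrogen in place of bromo on the aromatic carbon of the fused system gives no change at the digits printed from compound 2 to compound 3 (within the scatter), and this is the first look at this place, since the earlier step changed only the aryl group on the saturated ring and kept the bromo. For this pair, losing the one heavy atom at this place leaves the read-out within the scatter, so at this single dose the bromo is not needed to keep this level of inhibition, although a percentage at one dose is not a potency and equal readings here do not prove equal potency at other doses. No measurement at hand gives a reason for this result.

Only bromo and hydrogen are shown at this place, so it remains open whether a larger or quite different group, such as an amine or a carboxylic acid, would also leave the read-out level. Going by these compounds, it is also open whether the same swap would read alike with the 4-hydroxyphenyl group of compound 1 on the saturated ring.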